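The compounds below may be only part of what the source reports. "The series", "measured", "known", "first", "only" and "open" are said of these compounds alone.

Three compounds share one core and differ only in the group on the amide nitrogen. In a functional assay on MGC-803 cells (Homo sapiens) for inhibition, read by MTT assay, with a stated time of 72 h (a higher number here means a weaker inhibitor, a lower number a stronger inhibitor), compound 1 `O=C(CSc1nc(Nc2ccccc2)c2ccccc2n1)Nc1ccccc1F` gives 10700 nM, compound 2 `O=C(CSc1nc(Nc2ccccc2)c2ccccc2n1)Nc1ccccc1Br` gives 18600 nM, and compound 3 `COc1cccc(NC(=O)CSc2nc(Nc3ccccc3)c3ccccc3n2)c1` gives 10000 nM. Because a 1.7-fold higher number from compound 1 to compound 2 (0.24 log units; within the scatter) and a 1.1-fold lower number from compound 1 to compound 3 (0.03 log units; within the scatter) and a 1.9-fold lower number from compound 2 to compound 3 (0.27 log units; within the scatter) are all within the scatter, compound 2 stands level with the other two in this assay.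

Compound 4 `CCc1ccc(NC(=O)CSc2nc(Nc3ccccc3)c3ccccc3n2)cc1` is the next step from compound 2: 4-ethylphenyl in place of 2-bromophenyl on an amide-type nitrogen. The step that bears on this change most directly is a 1.9-fold lower number from compound 2 to compound 3 (0.27 log units; within the scatter), which swapped out the same group without effect beyond the scatter. No step beyond the scatter is therefore expected; the step of a 1.3-fold lower number from compound 2 to compound 4 (0.12 log units; within the scatter) is the estimate. Compound 4 is expected to give about 14000 nM in this assay, between 6000 nM and 35000 nM.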

Compound 4, half-maximal inhibitory concentration: > 50000 nM
Compound 4: only a limit was reported; the forecaster's own chance of this, stated with the estimate: 10%; middle value at least 3.5-fold (0.55 log units) away from the limit.
By their numbers in this assay, from the lowest: compounds 3, 1 and 2 (each within the scatter of the next). At a limit, above all of these: compound 4.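

Among these compounds, until this result, no change to the group on the amide nitrogen had moved the number beyond the scatter, but 4-ethylphenyl makes a clear difference in this assay, giving a weaker inhibitor: an at least 2.6-fold higher number from compound 2 to compound 4 (0.42 log units; beyond the scatter), an at least 5.0-fold higher number from compound 3 to compound 4 (0.69 log units; beyond the scatter) and an at least 4.6-fold higher number from compound 1 to compound 4 (0.66 log units; beyond the scatter). The reading for compound 4 is a limit, not a number: the limit of > 50000 nM in this assay, at which 1 of the 4 values shown sits. As far as these compounds go, these steps therefore give only a smallest size, and their full size remains unknown.

Still open, from the compounds shown here alone, is whether the loss follows the ethyl group itself or the substitution pattern of its ring. A 2-ethylphenyl or 4-bromophenyl group on the amide nitrogen would help separate the two.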